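Benzyl swap on the trimethoxyphenyl amide series

The compounds below may be only part of what the source reports. "The series", "measured", "known", "first", "only" and "open" are said of these compounds alone.

Measured so far:
compound 1 `COc1cc(N(Cc2ccccc2)C(=O)CSc2nc3ccccc3s2)cc(OC)c1OC`: 44300 nM
compound 2 `COc1ccc2nc(SCC(=O)N(Cc3ccc(OC)c(O)c3)c3cc(OC)c(OC)c(OC)c3)sc2c1`: 71 nM
compound 3 `COc1cc(N(Cc2ccc(F)cc2)C(=O)CSc2nc3ccccc3s2)cc(OC)c1OC`: > 80000 nM

In a functional assay on MGC-803 cells (Homo sapiens) for antiproliferative activity, read by MTT assay, with a stated time of 48 h (on this read-out higher numbers stand for weaker inhibition and lower numbers for stronger inhibition), compound 1 gives 44300 nM. Compound 2 gives 71 nM in this assay. Compound 3 gives only a limit in this assay, > 80000 nM, so it has no number of its own and stands at the weak end of what has been measured. For the measured compounds named here, the single measured step that touches the benzyl position is an at least 1.8-fold higher number from compound 1 to compound 3 (0.25 log units; that floor lies within the scatter); it starts from a weak compound and ends at the limit (the limit of > 80000 nM in this assay, at which 1 of the 3 values shown sits), so its true size is not known.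

Compound 4 `COc1ccc(CN(C(=O)CSc2nc3ccccc3s2)c2cc(OC)c(OC)c(OC)c2)cc1O` is not yet measured. It carries 3-hydroxy-4-methoxyphenyl in place of 4-fluorophenyl on a saturated chain carbon bound to an amide-type nitrogen. Compound 2 bears the same 3-hydroxy-4-methoxybenzyl group on its amide nitrogen and gives 71 nM. A large fall in number is therefore expected, an at least 400-fold lower number from compound 3 to compound 4 (2.60 log units; beyond the scatter), because compound 2 gives 71 nM with this benzyl group in place. For compound 4 the estimate in this assay is 200 nM, within 40 nM to 1500 nM.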

Compound 4, half-maximal inhibitory concentration: 35 nM
Compound 4: the middle estimate sits 5.7-fold (0.76 log units) above what was measured; the measured number lies below the stated range.
By their numbers in this assay, from the lowest: compound 4; then compound 2; then compound 1. At a limit, above all of these: compound 3.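

In this assay, 3-hydroxy-4-methoxyphenyl in place of phenyl on a saturated chain carbon bound to an amide-type nitrogen gives a 1300-fold lower number from compound 1 to compound 4 (3.10 log units; beyond the scatter), so this position now has a step of measured size on the unsubstituted core. The step of an at least 2200-fold lower number from compound 3 to compound 4 (3.35 log units; beyond the scatter) is only a floor, set by a limit on compound 3: the limit of > 80000 nM in this assay, at which 1 of the 4 values shown sits. The methoxy on the core of compound 2 is not needed for the low number, since hydrogen in its place gives a 2.0-fold lower number from compound 2 to compound 4 (0.31 log units; beyond the scatter), a modest step.

The compounds shown do not separate the hydroxy from the methoxy of the 3-hydroxy-4-methoxybenzyl group, so which of the two carries the step stays open. Also open, going by these compounds, is how an amine in place of the hydroxy, or a longer chain in place of the benzyl group, would read in this assay.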